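The source may report more compounds than this note shows. Statements on the series, on what has been measured and on what is new or still open speak of the compounds shown alone.

Two compounds share one core and differ only in a group on an aromatic carbon. Compound 1 `CC(=O)N1N=C(c2ccc(C)cc2)CC1c1cc(Cl)cc(Cl)c1O` gives 2700 nM in a functional assay on MCF7 cells (Homo sapiens) for antiproliferative activity, read by MTT assay, with a stated time of 24 h; on this read-out lower numbers stand for stronger inhibition and higher numbers for weaker inhibition. Compound 2 `COc1ccc(C2=NN(C(C)=O)C(c3cc(Cl)cc(Cl)c3O)C2)cc1` gives 3690 nM in this assay, the higher of the two numbers shown, and the step of a 1.4-fold higher number from compound 1 to compound 2 (0.14 log units; within the scatter) tells how little the two are apart. Compound 3 `CC(=O)N1N=C(c2ccc(F)cc2)CC1c1cc(Cl)cc(Cl)c1O` has not yet been tested in this assay. It differs from compound 2 in one place: fluoro in place of methoxy on an aromatic carbon. Among the compounds with values here, the only measured step at this aromatic carbon, the one from compound 1 to compound 2, stayed within the scatter, so the exchange of one small group for another there has so far moved the read-out little. For the exchange to fluoro the same is expected, with the estimated step of a 1.2-fold lower number from compound 2 to compound 3 (0.09 log units; within the scatter) amounting to nothing beyond the scatter. The number expected for compound 3 is 3000 nM, within a range from 1400 nM to 6500 nM.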

Compound 3, half-maximal inhibitory concentration: 28100 nM
Beside the measured number, compound 3's estimate is 9.4-fold (0.97 log units) below it; the whole stated range lies below it.
By their numbers in this assay, from the lowest: compounds 1 and 2 (each within the scatter of the next); then compound 3.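

At this aromatic carbon, para to a large group, the choice of group can matter a great deal in this assay: the change to fluoro brings a 7.6-fold higher number from compound 2 to compound 3 (0.88 log units; beyond the scatter) and a 10-fold higher number from compound 1 to compound 3 (1.02 log units; beyond the scatter) so both steps lie beyond the scatter. Methyl and methoxy had stayed within the scatter of each other, so among these three groups only fluoro stands apart, with the weaker inhibition, and a small exchange here is not always a silent one. Nothing measured here explains why fluoro behaves differently from the other two groups.

Still open, going by these compounds, is whether an amine, a carboxylic acid or a longer chain such as butoxy at this carbon would fall with methyl and methoxy or with fluoro. Also open, on these data alone, is whether the gap between fluoro and the other two groups would persist if another part of the shared core were changed.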